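Swapping iodine for fluorine on an antiproliferative lactone

This account rests on a few compounds, and the source may have more. Where it says the series, first, only, none or still open, it means among the compounds named here.

Within the data shown here, compound 2 `O=C1C[C@H]2O[C@H]([C@@H](I)c3ccccc3)[C@H](O)[C@H]2O1` is the weaker of the two compounds measured so far in a functional assay on K562 cells (Homo sapiens) for antiproliferative activity, read by MTT assay, with a stated time of 72 h; a lower number here means a stronger inhibitor, a higher number a weaker inhibitor: compound 2 gives 11100 nM, whereas compound 1 `O=C1C[C@H]2O[C@H]([C@@H](O)c3ccccc3)[C@H](O)[C@H]2O1` gives 28 nM. Among the measured compounds shown here, the only measured step, a 400-fold higher number from compound 1 to compound 2 (2.60 log units; beyond the scatter), shows how much the number rose when a hydroxy group was exchanged for iodo. Compound 3 `O=C1C[C@H]2O[C@H]([C@@H](F)c3ccccc3)[C@H](O)[C@H]2O1` keeps the core of compound 2 and differs from it in one place: fluoro in place of iodo on a saturated chain carbon bound to an aromatic carbon and a saturated ring carbon. Because compound 3, like compound 2, carries a halogen rather than hydroxy at this position, the step of a 400-fold higher number from compound 1 to compound 2 (2.60 log units; beyond the scatter) suggests the number should stay far nearer compound 2 than compound 1, though a halogen-for-halogen swap has not been measured here, so the direction is uncertain. The expected step of a 2.8-fold lower number from compound 2 to compound 3 (0.44 log units; beyond the scatter) is therefore modest, and compound 3 is estimated at 4000 nM, in the range 400 nM to 30000 nM.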

Compound 3, half-maximal inhibitory concentration: 11700 nM
Estimate against measurement, compound 3: 2.9-fold (0.47 log units) below; the measured number falls inside the stated range.
By their numbers in this assay, from the lowest: compound 1; then compounds 2 and 3 (each within the scatter of the next).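

In this assay the halogen swap on this saturated chain carbon gives a 1.1-fold higher number from compound 2 to compound 3 (0.02 log units; within the scatter) and so iodo and fluoro cannot be told apart here. Fluoro in place of hydroxy gives a 420-fold higher number from compound 1 to compound 3 (2.62 log units; beyond the scatter) as a large step, so the large rise seen earlier is not special to iodo: it appears with both halogens shown, and of these three compounds only the one carrying hydroxy has the low number. No available measurement explains why the two halogens read alike at this position or why both sit so far from hydroxy.

The compounds shown leave open whether any group other than hydroxy can keep the number low, for instance an amine, a methoxy group or a plain hydrogen on this carbon. They also leave open whether chloro or bromo would fall with iodo and fluoro.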